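Vero cell cytotoxicity notes on four related compounds

A few compounds are considered here, and "the series" means these few. Any claim that something is new, unique, unknown or untested is made for them only; others in the source may bear on it.

Measured so far in an ADME assay on Vero cells (Chlorocebus sabaeus) for cytotoxicity, read by resazurin assay, with a stated time of 3 days; a lower number here means a stronger inhibitor, a higher number a weaker inhibitor:

compound 1 `CCCCNC(=O)Nc1cc2nc(C3CCCCC3)[nH]c2cc1N(CC)CC` gives > 100 ug/mL
compound 2 `CCCCOC(=O)Nc1cc2nc(C3CCCCC3)[nH]c2cc1N(CC)CCN(C)C` gives > 100 ug/mL
compound 3 `CCCNC(=O)Nc1cc2nc(C3CCCCC3)[nH]c2cc1N(CC)CC` gives > 100 ug/mL

Each of these three values is a limit of this assay and not a number. For compound 1 the value > 100 ug/mL is such a limit. For compound 3 the value > 100 ug/mL is likewise a limit. For compound 2 the value > 100 ug/mL is also only a limit. All three therefore sit together at the limit of > 100 ug/mL in this assay, at which 3 of the 3 values shown sit.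

Compound 3 differs from compound 1 by hydrogen in place of methyl on a saturated chain carbon, three bonds along the chain from an amide-type nitrogen. The step that the two limits leave unreadable from compound 1 to compound 3 cannot be read, as both ends are limits. The difference between the core of compound 1 and the core of compound 2 is not broken down here.

Compound 4 `CCCCOC(=O)Nc1cc2nc(C3CCCCC3)[nH]c2cc1N(C)CCN(C)C` is not yet measured. It differs from compound 2 by hydrogen in place of methyl on a saturated chain carbon bound to a nitrogen on an aromatic ring. This is the same kind of change as from compound 1 to compound 3, not the same one: there the carbon sits three bonds along the chain from an amide-type nitrogen, here it is bound to a nitrogen on an aromatic ring.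

In this assay compound 4 is expected to give 150 ug/mL, with a likely range from 80 ug/mL to 400 ug/mL. The expected step that the limit leaves unreadable from compound 2 to compound 4 is small. This expectation rests on compound 2 standing at > 100 ug/mL and on the three measured values gathering at the limit of > 100 ug/mL in this assay, at which 3 of the 3 values shown sit.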

Compound 4, half-maximal inhibitory concentration: > 100 ug/mL
Compound 4 ended at the assay's limit (the forecaster's own chance of this, stated with the estimate: 80%); the middle value is on the limit's open side.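

No new step can be read: compound 2 and compound 4 both stand at a limit of this assay, not at a number, so the change from ethyl to methyl cannot be sized. The compounds shown leave open whether any change among them alters the half-maximal inhibitory concentration, as no value in the series is a number: the limit of > 100 ug/mL in this assay, at which 4 of the 4 values shown sit.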